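A Longer Arm on the Saturated Ring Carbon

A few compounds are considered here, and "the series" means these few. Any claim that something is new, unique, unknown or untested is made for them only; others in the source may bear on it.

Of the compounds shown here, three have so far been measured in a functional assay on the whole organism (strain Wistar albino) for inhibition, with Rattus norvegicus as the target, read by paw edema, with stated times of 30 min and 3 h, at a dose of 0.05 mmol/kg; a lower number here means less inhibition, a higher number more inhibition at the dose given (going by the name of the read-out). Compound 1 `NS(=O)(=O)c1ccc(N2N=C(c3cccc(O)c3)C[C@H]2c2ccccc2)cc1` gives 35.8%, compound 2 `Cc1ccc([C@@H]2CC(c3cccc(O)c3)=NN2c2ccc(S(N)(=O)=O)cc2)cc1` gives 64.7%, and compound 3 `NS(=O)(=O)c1ccc(N2N=C(c3cccc(O)c3)C[C@H]2c2ccccc2Cl)cc1` gives 32.6%. Compound 1 stands second of the three; compound 3 lies within the scatter of it, while compound 2 sits well above it. The measured steps are a number 28.9 percentage points higher from compound 1 to compound 2 (beyond the scatter), a number 3.2 percentage points lower from compound 1 to compound 3 (within the scatter) and a number 32.1 percentage points lower from compound 2 to compound 3 (beyond the scatter). Compound 4 `NS(=O)(=O)c1ccc(N2N=C(c3cccc(O)c3)C[C@H]2/C=C/c2ccccc2)cc1` differs from compound 1 in one place: 2-phenylethenyl in place of phenyl on a saturated ring carbon. For the measured compounds named here, none of the measured steps makes a change of this kind; each only swaps a hydrogen on an aromatic carbon of that group. They show that changes at this site can shift the read-out modestly or greatly, yet give no direction for this one. Compound 4 is therefore expected to lie near compound 1, the step of a number 4.2 percentage points higher from compound 1 to compound 4 (within the scatter) expected small. The estimate for compound 4 is 40%, within 22% to 62%.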

Compound 4, a percentage reported as inhibition, in the whole organism at one dose (the size of the read-out at that dose, not a potency): 39.9%
For compound 4 the middle estimate is 0.1 percentage points above the measured one, and the stated range covers the measured number.
By their numbers in this assay, from the lowest: compounds 3, 1 and 4 (each within the scatter of the next); then compound 2.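

In this assay, putting the longer 2-phenylethenyl group on the saturated ring carbon leaves the read-out within the scatter of the two ring-bearing neighbours, with a number 4.1 percentage points higher from compound 1 to compound 4 (within the scatter) and a number 7.3 percentage points higher from compound 3 to compound 4 (within the scatter). The 4-methylphenyl compound still stands apart, with a number 24.8 percentage points lower from compound 2 to compound 4 (beyond the scatter), so this longer arm with its double bond does not match that group. No measurement at hand explains these steps.

From the compounds shown here alone, what a saturated 2-phenylethyl group or an amine on this carbon would give remains open. Also open, going by these compounds, is whether a methyl on the aromatic ring of the 2-phenylethenyl group would repeat a number 28.9 percentage points higher from compound 1 to compound 2 (beyond the scatter).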